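The compounds below may be only part of what the source reports. "The series", "measured", "known", "first", "only" and "open" are said of these compounds alone.

Series notes, aryl sulfonyl hydrazides. Of the compounds shown here, two carry numbers so far. Compound 1 `Cc1cccc(NNS(=O)(=O)c2ccc(C#N)cc2)c1` is the weaker of the pair: in an assay on HeLa cells for inhibition of Indoleamine 2,3-dioxygenase 1 (Homo sapiens), read by spectrophotometry, with a stated time of 24 h (on this read-out higher numbers stand for an effect only at larger amounts of compound and lower numbers for an effect already at smaller amounts), compound 1 gives 3400 nM. Compound 2 `CC(=O)Nc1ccc(S(=O)(=O)NNc2ccc(C#N)cc2)cc1` carries the acetamido group on the sulfonyl-bearing ring and the nitrile on the hydrazine-bearing ring; in this assay compound 2 gives 1390 nM, the lowest of the two numbers, and its distance from compound 1 lies beyond the usual scatter. For the measured compounds named here, the two compounds differ in more than one place, so no single step between them can be read off.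

Compound 3 `CC(=O)Nc1ccc(S(=O)(=O)NNc2ccc(Cl)cc2)cc1` follows from compound 2 by one change: chloro in place of cyano on an aromatic carbon. Nothing in the measured pair speaks to this exchange on its own, so the expectation rests on the change alone. A small step is expected, and none is asserted beyond the scatter; if anything, a modest move toward a higher number is expected from compound 2 to compound 3, a 1.4-fold higher number from compound 2 to compound 3 (0.16 log units; within the scatter). For compound 3 the expected value in this assay is 2000 nM, with a range from 700 nM to 6000 nM.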

Compound 3, half-maximal effective concentration: 142 nM
For compound 3 the middle estimate is 14-fold (1.15 log units) above the measured one, and the stated range ends above it.
By their numbers in this assay, from the lowest: compound 3; then compound 2; then compound 1.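

In this assay, the exchange of cyano for chloro on an aromatic carbon, para to a large group, gives a 9.8-fold lower number from compound 2 to compound 3 (0.99 log units; beyond the scatter), so this position is not indifferent to the group it carries, and a single replacement here moves the number beyond the scatter. The exchange removes a group with a triple bond and a hydrogen-bond acceptor and puts in a lone chlorine with no acceptor, but this single pair cannot separate those differences or show which of them goes with the lower number. For the compounds shown here, nothing measured so far bears on the reason for this step.

From the compounds shown here alone, it remains open whether the lower number is particular to chloro or also holds for other groups at this position, such as fluoro, bromo, methyl, methoxy or an amine. Going by these compounds, it is equally open whether the exchange carries the same weight when the acetamido group elsewhere on the shared core gives way to a free amine, a carboxylic acid or a longer chain.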